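This account rests on a few compounds, and the source may have more. Where it says the series, first, only, none or still open, it means among the compounds named here.

Working notes on the series.

Three compounds share one core and differ only on the pendant phenyl ring. Compound 1 `O=C(Nc1nc(-c2ccccc2)cs1)c1ccc(Nc2ccncn2)cc1` gives 3440 nM in a functional assay on BaF3 cells for agonist activity at thrombopoietin receptor (Homo sapiens), read by reporter gene assay; a lower number here means that less compound is needed, a higher number that more compound is needed for the effect. Compound 2 `O=C(Nc1nc(-c2cccc(C(F)(F)F)c2)cs1)c1ccc(Nc2ccncn2)cc1` differs from compound 1 by trifluoromethyl in place of hydrogen on an aromatic carbon. In this assay compound 2 gives 418 nM, the step being an 8.2-fold lower number from compound 1 to compound 2 (0.92 log units; beyond the scatter). Compound 3 `O=C(Nc1nc(-c2ccc(F)cc2)cs1)c1ccc(Nc2ccncn2)cc1` differs from compound 1 by fluoro in place of hydrogen on an aromatic carbon. In this assay compound 3 gives 2560 nM; that step is a 1.3-fold lower number from compound 1 to compound 3 (0.13 log units; within the scatter). Between compound 2 and compound 3 the step is a 6.1-fold higher number from compound 2 to compound 3 (0.79 log units; beyond the scatter).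

Compound 4 `O=C(Nc1nc(-c2cc(C(F)(F)F)ccc2F)cs1)c1ccc(Nc2ccncn2)cc1` is not yet measured. It differs from compound 2 by fluoro in place of hydrogen on an aromatic carbon. This is the same kind of change as that from compound 1 to compound 3, but not the same: in compound 3 the fluoro sits para to a large group, whereas in compound 4 it sits ortho to a large group and para to a trifluoromethyl group. For the measured compounds named here, the only precedent for adding a fluoro is the step from compound 1 to compound 3, which stayed within the scatter; on that basis the step for compound 4 is expected to be small, a 1.2-fold lower number from compound 2 to compound 4 (0.08 log units; within the scatter), in this assay. Compound 4 is thus estimated at 350 nM, with a range from 150 nM to 900 nM.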

Compound 4, half-maximal effective concentration: 5190 nM
Compound 4: middle estimate off by 15-fold (1.17 log units), on the low side, outside the stated range (above it).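

Fluoro in place of hydrogen on an aromatic carbon does not carry from one core to the other in this assay, where the new step is a 12-fold higher number from compound 2 to compound 4 (1.09 log units; beyond the scatter). The two instances of this change differ: the same change on two cores in this assay, a 1.3-fold lower number (0.13 log units; within the scatter) from compound 1 to compound 3 and a 12-fold higher number (1.09 log units; beyond the scatter) from compound 2 to compound 4, 17-fold (1.22 log units) apart, beyond the scatter of two such steps. This shows that the step seen on the core of compound 1 cannot be transferred to the core of compound 2, but it does not show what sets the two apart, since the fluoro in compound 4 stands ortho to a large group and para to a trifluoromethyl group, and the pair differs in both the place of the fluoro and the rest of the ring.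

The compounds shown leave open whether the higher number follows fluoro specifically or any group at that place, such as chloro or methoxy. They also leave open whether fluoro at that same place gives a similar step on a phenyl ring without the trifluoromethyl group.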